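Urea substituent change in a sulfamide series

The source may report more compounds than this note shows. Statements on the series, on what has been measured and on what is new or still open speak of the compounds shown alone.

In a functional assay on the whole organism (blood) with Rattus norvegicus as the target, with stated times of 24 h and 1 h, at a dose of 5 mg/kg by the intraperitoneal route (on this read-out higher numbers stand for a stronger effect at the one dose given and lower numbers for a weaker effect), compound 1 `COc1ccc(Cl)cc1C(=O)NCC1CCN(S(=O)(=O)NC(=O)NC2CCCCC2)CC1` gives 20%. Going by the values given here, compound 2 `COc1ccc(Cl)cc1C(=O)NCCC1CCN(S(=O)(=O)NC(=O)NC[C@@H]2C[C@@H]3C=C[C@@H]2C3)CC1` gives 37% in this assay, the highest of the two numbers so far; compound 1 sits lower by a gap beyond the usual scatter. Compound 3 `COc1ccc(Cl)cc1C(=O)NCCC1CCN(S(=O)(=O)NC(=O)NN2CCCCCC2)CC1` differs from compound 2 in one place: a group of 7 heavy atoms (6 carbon, 1 nitrogen; one seven-membered non-aromatic ring with 1 hetero atom) in place of a group of 8 heavy atoms (8 carbon; 2 five-membered non-aromatic rings of carbon only), on an amide-type nitrogen. Among the compounds with values here, no measured pair shows this change, so the expected step of a number 9 percentage points lower from compound 2 to compound 3 (within the scatter) is a modest fall, not clearly beyond the scatter. Compound 3 is expected to give 28%, within 10% to 48% in this assay.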

Compound 3, a percentage reported as activity, at one dose (the size of the read-out at that dose, not a potency): 36%
For compound 3 the middle estimate is 8 percentage points below the measured one, within the range that was stated.
By their numbers in this assay, from the lowest: compound 1; then compounds 3 and 2 (each within the scatter of the next).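

On the amide-type nitrogen whose other neighbour is the carbonyl carbon, replacing the group of two five-membered carbon rings with azepan-1-yl gives a number 1 percentage points lower from compound 2 to compound 3 (within the scatter) in this assay. At this dose, the read-out therefore does not separate the two groups, even though the change removes the double bond and all three defined stereocentres and adds a ring nitrogen. No available measurement explains this result.

On these data alone, whether an open chain such as n-hexyl or a small methyl group at this position would also stay within the scatter remains open. So does whether the two ring groups would still match at other doses.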